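Methoxy on the phenyl of compound 1: expected inhibition

This account rests on a few compounds, and the source may have more. Where it says the series, first, only, none or still open, it means among the compounds named here.

Measured so far:
- compound 1 `Cc1cccc2c1N(CC(=O)O)C/C(=C\c1ccccc1)C2=O`: 27.9% in an assay on HL-60 cells for inhibition of glutathione S-transferase P (Homo sapiens), read by spectrophotometry, tested at 20 uM; on this read-out higher numbers stand for more inhibition at the one concentration tested (going by the name of the read-out) and lower numbers for less inhibition
- compound 2 `Cc1ccc2c(c1)C(=O)/C(=C/c1ccc(F)cc1)CN2CC(=O)O`: 16.1% in this assay
- compound 3 `CCOc1ccc(/C=C2\CN(CC(=O)O)c3ccc(C)cc3C2=O)cc1`: 25.8% in this assay

Compound 1 carries the highest of the three numbers, but compound 3 is not separated from it by more than the usual scatter; only compound 2 sits clearly lower, its gap to compound 1 lying beyond the scatter. The shared core is the same throughout; the compounds differ on the phenyl and on the core itself.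

Compound 4 `COc1ccc(/C=C2\CN(CC(=O)O)c3c(C)cccc3C2=O)cc1` has not been measured in this assay. It differs from compound 1 by methoxy in place of hydrogen on an aromatic carbon.

Among the compounds with values here, one measured step bears on this: a number 9.7 percentage points higher from compound 2 to compound 3 (within the scatter), an exchange on the same aromatic carbon of the phenyl, and it stayed within the scatter. That step replaced one group by another rather than adding one to hydrogen, so it is only a partial guide. On this basis no step beyond the scatter is expected from compound 1 to compound 4, perhaps a small rise; the expected step is a number 3.1 percentage points higher from compound 1 to compound 4 (within the scatter).

For compound 4 the estimate in this assay is 31%, with a range from 19% to 43%.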

Compound 4, a percentage reported as inhibition, at one concentration (the size of the read-out at that concentration, not a potency): 31.5%
Beside the measured number, compound 4's estimate is 0.5 percentage points below it; the range from low to high includes it.
By their numbers in this assay, from the lowest: compounds 2, 3, 1 and 4 (each within the scatter of the next, the first and the last beyond it).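

Methoxy on an aromatic carbon of the phenyl, para to a large group, gives in this assay a number 3.6 percentage points higher from compound 1 to compound 4 (within the scatter) and is the first change in the series that adds a group where hydrogen stood, rather than exchanging one group for another. Going from phenyl to 4-methoxyphenyl on the core of compound 1 therefore leaves the inhibition reading within the scatter, so this carbon accepts the added methoxy without a clear loss or gain at the one concentration tested, and the earlier fluoro-to-ethoxy exchange, made on a different core, could not show this directly. No information is available on why the reading responds to this change as it does.

Whether the position stays this flat for other groups is open: an amine, a carboxylic acid or a longer alkoxy chain on the same carbon could still move the number beyond the scatter. Within the data shown here, also open is how fluoro at this carbon behaves on the core of compound 1, since the only fluoro compound here, compound 2, carries its methyl elsewhere on the core.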